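Methoxy for Methyl, Tried on a Second Core

The compounds below may be only part of what the source reports. "The series", "measured", "known", "first", "only" and "open" are said of these compounds alone.

Compound 2 `Cc1ccc(Cn2cc(CSC(=S)N3CCN(C(=O)OCc4ccccc4)CC3)nn2)cc1` and compound 1 `COc1ccc(Cn2cc(CSC(=S)N3CCN(C(=O)OCc4ccccc4)CC3)nn2)cc1` share one core and differ only in that (methoxy in place of methyl on an aromatic carbon). In a functional assay on ECa-109 cells (Homo sapiens) for inhibition, read by MTT assay, with a stated time of 72 h (a lower number here means a stronger inhibitor, a higher number a weaker inhibitor), compound 2 gives 32600 nM, while compound 1 gives 58300 nM, so the step is a 1.8-fold higher number from compound 2 to compound 1 (0.25 log units; within the scatter). Compound 3 `Cc1ccc(Cn2cc(CSC(=S)N3CCNCC3)nn2)cc1` keeps the methyl group, but its core differs from that of compound 2 in that (hydrogen in place of benzyloxycarbonyl on an amine nitrogen in a ring). In this assay compound 3 reaches only a limit of the assay, > 128000 nM. The step of an at least 3.9-fold higher number from compound 2 to compound 3 (0.59 log units; beyond the scatter) rests on (the limit of > 128000 nM in this assay, at which 1 of the 3 values shown sits). Compound 4 `COc1ccc(Cn2cc(CSC(=S)N3CCNCC3)nn2)cc1` is not yet measured; it differs from compound 3 in that (methoxy in place of methyl on an aromatic carbon), the same change already seen between compound 2 and compound 1. Because the earlier step of a 1.8-fold higher number from compound 2 to compound 1 (0.25 log units; within the scatter) stayed within the scatter, the expected step here is a step that the limit leaves unreadable from compound 3 to compound 4. For compound 4 the estimate is therefore 200000 nM, with a strong chance that only a limit is reported again.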

Compound 4, half-maximal inhibitory concentration: > 128000 nM
Compound 4 was reported as a limit; the forecaster's own chance of this, stated with the estimate: 80%; the middle value is on the limit's open side.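

In this assay compound 4 gives > 128000 nM, which is a limit of the assay and not a number. Compound 3 sits at the same limit, so the step from methyl to methoxy cannot be read on this core, and it remains unknown whether that change behaves as it did on the core of compound 2: the limit of > 128000 nM in this assay, at which 2 of the 4 values shown sit. Only the swap of benzyloxycarbonyl for hydrogen gives a readable result, an at least 2.1-fold higher number from compound 1 to compound 4 (0.34 log units; beyond the scatter), and it can be set beside the same swap in the methyl pair: the same change on two cores in this assay, an at least 3.9-fold higher number (0.59 log units; beyond the scatter) from compound 2 to compound 3 and an at least 2.1-fold higher number (0.34 log units; beyond the scatter) from compound 1 to compound 4; the limit leaves it open whether they differ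

The compounds shown leave open how methoxy for methyl behaves on any other core that gives a measurable value in this assay. Also open, from the compounds shown here alone, is whether a smaller group on that nitrogen, such as acetyl, would give a value rather than a limit.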